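Amino to Methyl on a Shared Core: Expected Potency

The source may hold more compounds than are shown below. What is called first, only, known or untested is meant among the compounds shown, and "the series" means these compounds.

Compound 1 `C#CCOc1ccc(-c2cc(-c3ccc(OCC#C)c(OCC)c3)nc(N)n2)cc1`, compound 2 `C#CCOc1ccc(-c2cc(-c3cccc(OCC#C)c3)nc(N)n2)cc1` and compound 3 `C#CCOc1ccc(-c2cc(-c3cccc(OCC#C)c3)nc(C)n2)cc1` were tested in an assay on BTI-TN-5B1-4 cells for inhibition of Amine oxidase [flavin-containing] A (Homo sapiens), read by fluorescence and Amplex Red, using microsomes, with a stated time of 30 min; a lower number here means a stronger inhibitor, a higher number a weaker inhibitor. Compound 1 came out as "not active" (no number reported). Compound 2 gives 24100 nM, and compound 3 gives 21100 nM. These two differ by methyl in place of amino on an aromatic carbon, and that step gave a 1.1-fold lower number from compound 2 to compound 3 (0.06 log units; within the scatter). As far as these compounds go, compound 4 `C#CCOc1ccc(-c2cc(-c3ccc(OCC#C)c(OCC)c3)nc(C)n2)cc1` is still untested; it differs from compound 1 by methyl in place of amino on an aromatic carbon, the same kind of change, although here the place is meta to a 4-(propargyloxy)phenyl group and meta to a large group, whereas in compound 3 it is meta to two large groups. How the cores of compound 1 and compound 2 differ is not broken down here. Compound 4 is expected to give about 60000 nM in this assay, most likely again without a reported number, because compound 1 gives "not active" (no number reported) and because the same kind of change gave only a 1.1-fold lower number from compound 2 to compound 3 (0.06 log units; within the scatter).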

Compound 4, half-maximal inhibitory concentration: "not active" (no number reported)
Nothing numeric was reported for compound 4, so the estimate cannot be set against anything.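

For the compounds shown here, compound 1 and compound 4 both came out without a number, so no step between them can be read. No measurement shown here offers an explanation for this result. The compounds shown leave open whether methyl in place of amino changes the potency on the core of compound 1.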